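This account rests on a few compounds, and the source may have more. Where it says the series, first, only, none or still open, it means among the compounds named here.

Of the compounds shown here, three have so far been measured in an assay on COS-7 cells for agonist activity at Free fatty acid receptor 1 (Homo sapiens), read by scintillation counting and inositol phosphate accumulation, with a stated time of 90 min; on this read-out higher numbers stand for an effect only at larger amounts of compound and lower numbers for an effect already at smaller amounts. Compound 1 `Cc1cccc(Nc2nc(N)nc(COc3ccc4c(C)cc(=O)oc4c3)n2)c1` gives 1780 nM in this assay. Compound 2 `CCCc1cc(=O)oc2cc(OCc3nc(N)nc(Nc4ccc(C)cc4)n3)ccc12` gives 2900 nM. Compound 3 `Cc1ccc(Nc2nc(N)nc(COc3cc(N4CCCC4=O)cc(C(F)(F)F)c3)n2)cc1Cl` gives 3190 nM. Of the three numbers, compound 3 has the highest, yet the gaps to both others lie within the usual scatter of repeated measurements: compound 2 is its nearest neighbour and compound 1 its furthest, and neither gap is wide enough to call one compound more or less active than another. All three share the same core and differ in the groups hung on it.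

Compound 4 `Cc1ccc(Nc2nc(N)nc(COc3cc(Cl)cc(N4CCCC4=O)c3)n2)cc1Cl` is not yet measured. It differs from compound 3 in a single place: chloro in place of trifluoromethyl on an aromatic carbon, in words, chloro in place of trifluoromethyl on an aromatic carbon. Within the data shown here, no pair among the measured compounds differs in only one place, so there is no measured step to lean on. The step from compound 3 to compound 4 is expected to be a 1.1-fold lower number from compound 3 to compound 4 (0.03 log units; within the scatter), that is, nothing beyond the scatter in either direction. Compound 4 is therefore estimated at 3000 nM, with a range from 1200 nM to 8000 nM.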

Compound 4, half-maximal effective concentration: 160 nM
Estimate against measurement, compound 4: 19-fold (1.27 log units) above; measured number outside the range, below it.
By their numbers in this assay, from the lowest: compound 4; then compounds 1, 2 and 3 (each within the scatter of the next).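

Among these compounds, this position on the aromatic ring, meta to a 2-oxopyrrolidin-1-yl group, turns out to matter a great deal in this assay: putting chloro in place of trifluoromethyl gives a 20-fold lower number from compound 3 to compound 4 (1.30 log units; beyond the scatter) and is the first single change whose effect can be read, since the earlier compounds differ in more than one place and their numbers offered no such step. The change looks modest on paper, with four heavy atoms leaving and one entering, no ring involved, no hydrogen-bond donor or acceptor gained or lost, and no net charge on either group, so these counts alone would not have flagged this carbon as sensitive. Nothing measured here explains why this exchange has so large an effect.

A single step cannot tell whether chloro itself is favourable or trifluoromethyl is unfavourable, and groups such as fluoro, bromo, methyl or a plain hydrogen on this carbon would help to separate the two. Also open, going by these compounds, is whether the same exchange has a similar effect when the groups elsewhere on the shared core are different.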